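Swapping 4-chlorophenyl for 3,4-dimethoxyphenyl in compound 3

The source may hold more compounds than are shown below. What is called first, only, known or untested is meant among the compounds shown, and "the series" means these compounds.

Measured in a functional assay on MCF7 cells (Homo sapiens) for inhibition, read by MTT assay, with a stated time of 48 h; on this read-out lower numbers stand for stronger inhibition of growth and higher numbers for weaker inhibition of growth:
- compound 1 `COc1ccc(C(=O)N2N=C(c3ccccc3)CC2c2cn(C)c3ccccc23)cn1`: 4310 nM
- compound 2 `Cn1cc(C2CC(c3ccccc3)=NN2C(=O)c2ccncc2)c2ccccc21`: 1110 nM
- compound 3 `Cn1cc(C2CC(c3ccc(Cl)cc3)=NN2C(=O)c2cccnc2)c2cc(Br)ccc21`: 8100 nM

Compound 3 at 8100 nM lies within the usual scatter of compound 1 at 4310 nM, and its number is clearly higher than that of compound 2 at 1110 nM. Compound 4 `COc1ccc(C2=NN(C(=O)c3cccnc3)C(c3cn(C)c4ccc(Br)cc34)C2)cc1OC` carries 3,4-dimethoxyphenyl in place of 4-chlorophenyl on a carbon with a double bond to nitrogen. Going by the values given here, the only measured step, a 3.9-fold lower number from compound 1 to compound 2 (0.59 log units; beyond the scatter), was modest and concerns a group on a carbonyl carbon, so it does not test this swap. No step beyond the scatter is therefore expected in this assay. The estimated change is a 1.5-fold lower number from compound 3 to compound 4 (0.17 log units; within the scatter). For compound 4 the estimated value is 5500 nM, with an expected range from 1800 nM to 17000 nM.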

Compound 4, concentration for 50% growth inhibition: 1170 nM
Estimate against measurement, compound 4: 4.7-fold (0.67 log units) above; measured number outside the range, below it.
By their numbers in this assay, from the lowest: compounds 2 and 4 (each within the scatter of the next); then compounds 1 and 3 (each within the scatter of the next).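

In this assay placing 3,4-dimethoxyphenyl in place of 4-chlorophenyl gives a 6.9-fold lower number from compound 3 to compound 4 (0.84 log units; beyond the scatter) and so shows that the group on this carbon with a double bond to nitrogen can shift the number beyond the scatter. Going by these compounds alone, the earlier step concerned only a group on a carbonyl carbon, so this is the first evidence on this position. No measurement here explains the shift.

As far as these compounds go, it remains open whether a single methoxy group would give the same step. Also open, from the compounds shown here alone, is how an amine or a carboxylic acid on the phenyl ring would read.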